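Removing the nitro group from compound 3

The source may hold more compounds than are shown below. What is called first, only, known or untested is meant among the compounds shown, and "the series" means these compounds.

In an ADME assay on L1210/0 cells (Mus musculus) for cytotoxicity, with a stated time of 48 h (on this read-out lower numbers stand for stronger inhibition and higher numbers for weaker inhibition), compound 1 (`O=C1O/C(=C\Cn2ccc(=O)[nH]c2=O)C(OCc2ccccc2)=C1OCc1ccccc1`) gives 12900 nM, and compound 2 (`CC(=O)OCCOCn1cnc2c(S)nc(F)nc21`) gives 40000 nM. Compound 3 (`Nc1nc(=O)n(COCCO)cc1[N+](=O)[O-]`) gives > 200000 nM, which is a limit of the assay and not a number. Compound 1 and compound 2 both lie on the stronger side of that limit. Compound 4 (`Nc1ccn(COCCO)c(=O)n1`) has hydrogen in place of nitro on an aromatic carbon, ortho to an amino group (hydrogen in place of nitro on an aromatic carbon). Among the compounds with values here, no two measured compounds differ in only one place, so no measured step guides this change. No shift beyond the usual scatter is expected in this assay, and the expected step is a number no higher from compound 3 to compound 4 (the limit leaves the size open). Compound 4 is estimated at 200000 nM, with a range of 80000 nM to 500000 nM.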

Compound 4, half-maximal inhibitory concentration: > 200000 nM
Compound 4: only a limit was reported; the forecaster's own chance of this, stated with the estimate: 70%; the middle value lies on the limit itself.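

Compound 3 and compound 4 both stop at a limit of the assay, not a number, so no step between them can be read: the limit of > 200000 nM in this assay, at which 2 of the 4 values shown sit.

The compounds shown leave open whether hydrogen in place of nitro changes cytotoxicity at all.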